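The source may report more compounds than this note shows. Statements on the series, on what has been measured and on what is new or still open speak of the compounds shown alone.

Compound 3 `Cc1cc(NC(=O)Cn2nnc(-c3ccc(F)cc3)n2)n(C2CCCCC2)n1` gives 92% in an assay on HEK293 cells for activation of Kir3.1/Kir3.2 (Homo sapiens), read by thallium flux (a lower number here means a smaller maximal response, a higher number a larger maximal response), and stands level with compound 1 `Cc1cc(NC(=O)Cn2nnc(-c3ccccc3)n2)n(C2CCCCC2)n1`, which in this assay gives 92%. Within the data shown here, compound 2 `Cc1nc(-c2ccccc2)c(NC(=O)Cn2nnc(-c3ccccc3)n2)s1` has a different core and in this assay is reported as "not active" (no number reported), with no number, so no step can be drawn from it. Compound 4 `COc1ccc(-c2nnn(CC(=O)Nc3cc(C)nn3C3CCCCC3)n2)cc1` differs from compound 3 by methoxy in place of fluoro on an aromatic carbon.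

Among the measured compounds shown here, the only measured step touching this aromatic carbon is no change at the digits printed from compound 1 to compound 3 (within the scatter), which lies within the scatter; it concerns fluoro against hydrogen and not methoxy, so it bears on the present change only indirectly. Nothing measured in this series speaks for a shift in the maximal response beyond the scatter when the group on this aromatic carbon is varied. The step from compound 3 to compound 4 is therefore expected to be a number 2 percentage points lower from compound 3 to compound 4 (within the scatter), within the scatter. For compound 4 the maximal response in this assay is estimated at 90%, with a range from 75% to 100%.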

Compound 4, largest response reached (Emax), in percent of the reference or control that the assay uses: 90%
Compound 4: the middle estimate sits on the measured number at the digits printed; the range from low to high includes it.
By their numbers in this assay, from the lowest: compounds 4, 1 and 3 (each within the scatter of the next).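

In this assay, the change from 4-fluorophenyl to 4-methoxyphenyl gives a number 2 percentage points lower from compound 3 to compound 4 (within the scatter), and methoxy in place of hydrogen on the same aromatic carbon gives a number 2 percentage points lower from compound 1 to compound 4 (within the scatter). The position para to a large group thus now carries hydrogen, fluoro or methoxy with no step beyond the scatter; before this result, only fluoro against hydrogen had been compared, and methoxy adds a group with a hydrogen-bond acceptor to that comparison. No measured data offer an explanation for this flat reading.

On these data alone, whether an amine, a carboxylic acid or a longer chain such as butoxy on this aromatic carbon would keep the maximal response level remains open. The compounds shown also leave open whether any group at this position can move the response beyond the scatter.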